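This account rests on a few compounds, and the source may have more. Where it says the series, first, only, none or still open, it means among the compounds named here.

Measured compounds in a functional assay on UACC-62 cells (Homo sapiens) for cytotoxicity, read by sulforhodamine B assay; a lower number here means a stronger inhibitor of growth, a higher number a weaker inhibitor of growth:
- compound 1, `CC1=CC[C@@H]([C@@](C)(O)CCCC(C)(C)NC(=S)N/N=C\c2ccccc2)CC1`: 43800 nM
- compound 2, `CC1=CC[C@@H]([C@@](C)(O)CCCC(C)(C)NC(=S)N/N=C\c2ccc(O)cc2)CC1`: 40100 nM
- compound 3, `CC1=CC[C@@H]([C@@](C)(O)CCCC(C)(C)NC(=S)N/N=C\c2ccc(Cl)cc2)CC1`: 13800 nM

Compound 3 stands lowest of the three numbers in this assay. The step of a 3.2-fold lower number from compound 1 to compound 3 (0.50 log units; beyond the scatter) and the step of a 2.9-fold lower number from compound 2 to compound 3 (0.46 log units; beyond the scatter) are both modest but beyond the scatter, whereas the step of a 1.1-fold lower number from compound 1 to compound 2 (0.04 log units; within the scatter) lies within the scatter, so compound 1 and compound 2 cannot be ordered against each other.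

Compound 4, `CC1=CC[C@@H]([C@@](C)(O)CCCC(C)(C)NC(=S)N/N=C(/C)c2ccccc2)CC1`, has not been measured. Its difference from compound 3 is a group of 9 heavy atoms (8 carbon, 1 nitrogen; one six-membered aromatic ring of carbon only) in place of a group of 9 heavy atoms (7 carbon, 1 nitrogen, 1 chlorine; one six-membered aromatic ring of carbon only), on an amide-type nitrogen. In effect the chloro on the aromatic carbon is gone and a methyl sits on the imine carbon instead; the core is unchanged.

Going by the values given here, only the steps to compound 3 bear on this change, and only in part: the step of a 3.2-fold lower number from compound 1 to compound 3 (0.50 log units; beyond the scatter) and the step of a 2.9-fold lower number from compound 2 to compound 3 (0.46 log units; beyond the scatter) show what the chloro contributed, so its removal is expected to give that back. Nothing measured speaks to the methyl on the imine carbon. As far as these compounds go, the expected outcome is therefore a return toward the number of compound 1, a modest step upward, a 2.9-fold higher number from compound 3 to compound 4 (0.46 log units; beyond the scatter), with a wide range because the methyl is untested. Compound 4 is estimated at 40000 nM, between 14000 nM and 110000 nM.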

Compound 4, concentration for total growth inhibition: 93300 nM
For compound 4 the middle estimate is 2.3-fold (0.37 log units) below the measured one; measured number inside the range.
By their numbers in this assay, from the lowest: compound 3; then compounds 2 and 1 (each within the scatter of the next); then compound 4.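

In this assay the methyl on the imine carbon is the only change in the step of a 2.1-fold higher number from compound 1 to compound 4 (0.33 log units; beyond the scatter), so the imine carbon, untested by the earlier compounds, is shown not to be neutral: this substitution gives a modest rise in the number, beyond the scatter. The same substitution also separates compound 4 from the hydroxy-bearing compound, with the step of a 2.3-fold higher number from compound 2 to compound 4 (0.37 log units; beyond the scatter), although that comparison also includes the loss of the hydroxy. The widest step in the set, a 6.8-fold higher number from compound 3 to compound 4 (0.83 log units; beyond the scatter), combines the loss of the chloro with the gain of the methyl, and both changes run towards a higher number, so the two together move the number further than either step from compound 1 does. No available evidence accounts for the effect of the methyl at this position.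

As far as these compounds go, whether the rise follows from the methyl alone or grows with an ethyl or a longer chain on the imine carbon remains open. Also open, from the compounds shown here alone, is whether a chloro on the aromatic carbon keeps its effect when the imine carbon carries a methyl, and what an amine at that aromatic carbon would give.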